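Fluoro Added to a Methyl-Bearing Analogue

The compounds below may be only part of what the source reports. "The series", "measured", "known", "first", "only" and "open" are said of these compounds alone.

Compound 1 `c1ccc(-c2ccc(-c3ccc(-c4nc5ccccc5[nH]4)cc3)cc2)cc1` is the starting point of this small series. In a functional assay on SiHa cells (Homo sapiens) for inhibition, read by sulforhodamine B assay (a lower number here means a stronger inhibitor of growth, a higher number a weaker inhibitor of growth), compound 1 gives 100000 nM. Compound 2 `Fc1ccc(-c2ccc(-c3ccc(-c4nc5ccccc5[nH]4)cc3)cc2)cc1` differs from it by fluoro in place of hydrogen on an aromatic carbon and in this assay compound 2 gives 29700 nM, which is a 3.4-fold lower number from compound 1 to compound 2 (0.53 log units; beyond the scatter). Compound 3 `Cc1ccc2[nH]c(-c3ccc(-c4ccc(-c5ccccc5)cc4)cc3)nc2c1` differs from compound 1 by methyl in place of hydrogen on an aromatic carbon and in this assay compound 3 gives 35200 nM, which is a 2.8-fold lower number from compound 1 to compound 3 (0.45 log units; beyond the scatter). The values of compound 2 and compound 3 lie within the usual scatter of each other.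

Compound 4 `Cc1ccc2[nH]c(-c3ccc(-c4ccc(-c5ccc(F)cc5)cc4)cc3)nc2c1` has not yet been measured. It differs from compound 3 by fluoro in place of hydrogen on an aromatic carbon. This is the same change that turns compound 1 into compound 2, now made on the core of compound 3; the two cores differ by the methyl described above, and the fluoro sits in the same kind of place in both cases. Because the earlier step was a 3.4-fold lower number from compound 1 to compound 2 (0.53 log units; beyond the scatter), the step expected here is a 2.9-fold lower number from compound 3 to compound 4 (0.47 log units; beyond the scatter). Compound 4 is therefore estimated to give 12000 nM in this assay, most likely between 5000 nM and 30000 nM.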

Compound 4, concentration for 50% growth inhibition: 41000 nM
Compound 4: the middle estimate sits 3.4-fold (0.53 log units) below what was measured; the measured number lies above the stated range.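

In this assay, fluoro in place of hydrogen on the methyl-bearing core gives a 1.2-fold higher number from compound 3 to compound 4 (0.07 log units; within the scatter), so the gain seen on the core of compound 1 does not carry over to this core: the same change on two cores in this assay, a 3.4-fold lower number (0.53 log units; beyond the scatter) from compound 1 to compound 2 and a 1.2-fold higher number (0.07 log units; within the scatter) from compound 3 to compound 4, 3.9-fold (0.59 log units) apart, beyond the scatter of two such steps

Read the other way round, methyl in place of hydrogen on the fluoro-bearing compound gives a 1.4-fold higher number from compound 2 to compound 4 (0.14 log units; within the scatter), and the gain that methyl brought without fluoro is likewise absent: the same change on two cores in this assay, a 2.8-fold lower number (0.45 log units; beyond the scatter) from compound 1 to compound 3 and a 1.4-fold higher number (0.14 log units; within the scatter) from compound 2 to compound 4, 3.9-fold (0.59 log units) apart, beyond the scatter of two such steps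

Both comparisons rest on the same four compounds, so they are one observation seen from two sides: the fluoro and methyl steps do not add up here, but these data do not show why, or whether the same would hold for other groups or cores.

The compounds shown leave open whether chloro, methoxy or an amine, placed on that aromatic carbon para to a large group, would give the same step on both cores as fluoro or would differ between them in the same way.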